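Shifting One Hydroxyl on a Shared Core

A few compounds are considered here, and "the series" means these few. Any claim that something is new, unique, unknown or untested is made for them only; others in the source may bear on it.

Measured compounds:
compound 1, `Oc1ccc(-c2cc(-c3cccs3)cc(-c3cccc(O)c3)n2)cc1`: 780 nM
compound 2, `Oc1ccc(-c2cc(-c3cccs3)cc(-c3ccc(O)cc3)n2)cc1`: 11700 nM
compound 3, `Oc1cccc(-c2cc(-c3ccsc3)cc(-c3cccc(O)c3)n2)c1`: 1510 nM

All three were tested in a functional assay on T47D cells (Homo sapiens) for cytotoxicity, read by CCK-8 assay; a higher number here means a weaker inhibitor, a lower number a stronger inhibitor. Compound 1 and compound 2 differ in one place: 4-hydroxyphenyl in place of 3-hydroxyphenyl on an aromatic carbon. That change gave a 15-fold higher number from compound 1 to compound 2 (1.18 log units; beyond the scatter). Compound 3 carries a different core from compound 1; the difference between the two cores is not broken down here. Compound 4, `Oc1ccc(-c2cc(-c3ccsc3)cc(-c3cccc(O)c3)n2)cc1`, is not yet measured and differs from compound 3 by 4-hydroxyphenyl in place of 3-hydroxyphenyl on an aromatic carbon. This is the same kind of change as in the first pair, though the surroundings differ: here the place is meta to a 3-hydroxyphenyl group and a thiophen-3-yl group, whereas in the first pair it was meta to a 4-hydroxyphenyl group and a thiophen-2-yl group. Because the first pair gave a 15-fold higher number from compound 1 to compound 2 (1.18 log units; beyond the scatter), a comparable rise is expected for compound 4, about a 9.9-fold higher number from compound 3 to compound 4 (1.00 log units; beyond the scatter). In this assay compound 4 is therefore estimated at 15000 nM, likely between 4000 nM and 50000 nM.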

Compound 4, half-maximal inhibitory concentration: 760 nM
The estimate for compound 4 lay 20-fold (1.30 log units) above the measured number, and the stated range ends above it.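

In this assay the same swap of 3-hydroxyphenyl for 4-hydroxyphenyl gave a 2.0-fold lower number from compound 3 to compound 4 (0.30 log units; within the scatter), so the large rise seen with the first pair did not carry over, and the size of this change depends on the core it sits on: the same change on two cores in this assay, a 15-fold higher number (1.18 log units; beyond the scatter) from compound 1 to compound 2 and a 2.0-fold lower number (0.30 log units; within the scatter) from compound 3 to compound 4, 30-fold (1.47 log units) apart, beyond the scatter of two such steps Swapping thiophen-2-yl for thiophen-3-yl gave a 1.0-fold lower number from compound 1 to compound 4 (0.01 log units; within the scatter), so that swap alone shows no effect here. The two pairs differ in both the thiophene and the other hydroxyphenyl group, and these compounds do not show which of the two sets the outcome.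

Still open, going by these compounds, is whether the swap would give a large rise on any further core. On these data alone, it is equally open how an amine or a carboxylic acid in place of the hydroxyl would behave on either core.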